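Sulfanyl for morpholinylamino on the amidine carbon

The compounds below may be only part of what the source reports. "The series", "measured", "known", "first", "only" and "open" are said of these compounds alone.

Compound 1, `CC1CCCC(C)N1CCCCCN1C(=O)C(c2ccc(Cl)c(Cl)c2)Oc2ccccc21`: 14%
Compound 2, `CC1CCCC(C)N1CCCCCN1C(=O)C(c2ccc(Cl)cc2)Oc2ccccc21`: 46%
Compound 3, `CC1CCCC(C)N1CCCCCN1C(=O)C(c2cccc(C(=N)NN3CCOCC3)c2)Oc2ccccc21`: 58%

In an assay on isolated protein for inhibition of serine protease 1 (Homo sapiens), tested at 100 uM (on this read-out higher numbers stand for more inhibition at the one concentration tested (going by the name of the read-out) and lower numbers for less inhibition), compound 3 gives 58%, the highest of the three numbers, and its gaps to the two others lie beyond the scatter. Compound 2 gives 46% in this assay, and compound 1 gives 14%. For the measured compounds named here, the only step between two compounds differing in one place is a number 32 percentage points higher from compound 1 to compound 2 (beyond the scatter), a change on the aromatic ring that carries the chloro group.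

Compound 4, `CC1CCCC(C)N1CCCCCN1C(=O)C(c2cccc(C(=N)S)c2)Oc2ccccc21`, differs from compound 3 in this way: sulfanyl in place of (morpholin-4-yl)amino on a carbon with a double bond to nitrogen. Going by the values given here, no measured step touches the carbon with a double bond to nitrogen, so the single step on record does not bear on this change, and it gives no guide to its size or direction. Compound 4 is therefore expected to move in this assay by a number 18 percentage points lower from compound 3 to compound 4 (beyond the scatter), a downward shift beyond the scatter held with low confidence. Compound 4 is estimated at 40%, within a range from 15% to 65%.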

Compound 4, a percentage reported as inhibition, at one concentration (the size of the read-out at that concentration, not a potency): 5.2%
Estimate against measurement, compound 4: 34.8 percentage points above; the measured number lies below the stated range.
By their numbers in this assay, from the lowest: compounds 4 and 1 (each within the scatter of the next); then compound 2; then compound 3.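

In this assay, for the compounds shown here, the carbon with a double bond to nitrogen proves sensitive to what it carries: sulfanyl in place of (morpholin-4-yl)amino gives a number 52.8 percentage points lower from compound 3 to compound 4 (beyond the scatter), a large step at a place no earlier pair had touched. Exchanging the whole group on the saturated ring carbon gives a number 40.8 percentage points lower from compound 2 to compound 4 (beyond the scatter), while the corresponding exchange against the group with two chlorine atoms gives a number 8.8 percentage points lower from compound 1 to compound 4 (within the scatter), so the sulfanyl compound does not separate from the dichloro compound. No measurement shown here bears on the reason for these steps.

The compounds shown leave open whether the ring, its oxygen or the nitrogen of the departing group matters most, or whether the entering sulfur itself counts. A plain amino group or a piperidin-1-ylamino group on the same carbon would begin to separate these possibilities.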